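A few compounds are considered here, and "the series" means these few. Any claim that something is new, unique, unknown or untested is made for them only; others in the source may bear on it.

Within the data shown here, compound 2 `CCCCc1ccc(N/N=C2\CCC(C)n3c2ncc(C(=O)O)c3=O)cc1` gives 7.8 umol/kg in a functional assay on the whole organism for inhibition, with Rattus norvegicus as the target (a higher number here means that more compound is needed for the effect, a lower number that less compound is needed), on the lower side of the two numbers so far, though compound 1 `CC1CC/C(=N\Nc2ccc(F)cc2)c2ncc(C(=O)O)c(=O)n21` with 12.2 umol/kg lies within the scatter of it. Among the measured compounds shown here, the one step between them, a 1.6-fold lower number from compound 1 to compound 2 (0.19 log units; within the scatter), changed the group on the same aromatic carbon that is now altered again. Compound 3 `CC1CC/C(=N\Nc2ccc(C3CC3)cc2)c2ncc(C(=O)O)c(=O)n21` carries the change (cyclopropyl in place of butyl on an aromatic carbon). For the measured compounds named here, with the only comparable step inside the scatter, no step beyond the scatter is expected in this assay in either direction. Compound 3 is therefore estimated at 8.5 umol/kg, in a range from 4 umol/kg to 18 umol/kg, expected as a step of a 1.1-fold higher number from compound 2 to compound 3 (0.04 log units; within the scatter).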

Compound 3, dose for 50% inhibition: 41.1 umol/kg
For compound 3 the middle estimate is 4.8-fold (0.68 log units) below the measured one; the whole stated range lies below it.
By their numbers in this assay, from the lowest: compounds 2 and 1 (each within the scatter of the next); then compound 3.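

This aromatic carbon, para to a large group, now gives steps beyond the scatter in this assay (cyclopropyl for butyl: a 5.3-fold higher number from compound 2 to compound 3 (0.72 log units; beyond the scatter); cyclopropyl for fluoro: a 3.4-fold higher number from compound 1 to compound 3 (0.53 log units; beyond the scatter)). Butyl and fluoro stayed within the scatter of each other, so the position does respond to its group, and among these three cyclopropyl stands apart. Nothing measured here gives a reason for this.

Open, from the compounds shown here alone, is whether the ring itself or the chain matters, which propyl on this carbon could separate from the cyclopropyl result. Also open, going by these compounds, is how a longer chain or an amine would read here.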